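Methoxy in Place of Chloro on Compound 1

The compounds below may be only part of what the source reports. "The series", "measured", "known", "first", "only" and "open" are said of these compounds alone.

Among the compounds with values here, in a functional assay on HCT-116 cells (Homo sapiens) for antiproliferative activity, read by MTT assay, with a stated time of 72 h (a lower number here means a stronger inhibitor, a higher number a weaker inhibitor), compound 1 (`O=S(=O)(c1ccc(-c2cnc(C3CC3)o2)cc1)N1CCCOc2ccc(Cl)cc21`) gives 39 nM as its result, the only true number available so far. Compound 2 (`O=S(=O)(c1ccc(-c2cnc(C3CC3)o2)cc1)N1CCC[S+]([O-])c2ccccc21`) gives > 1000 nM as its result, which is a limit and not a number. Compound 1 therefore serves as the one firm reference point, and it lies on the stronger side of that limit. Its structure differs from that of compound 2 in more than one place, so this gap cannot be pinned on any single group.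

Compound 3 (`COc1ccc2c(c1)N(S(=O)(=O)c1ccc(-c3cnc(C4CC4)o3)cc1)CCCO2`) keeps the core of compound 1 and changes one group: methoxy in place of chloro on an aromatic carbon. Within the data shown here, no measured pair shows this swap on its own, so the expectation starts from compound 1 at 39 nM and has to stay wide. The expected step of a 1.8-fold higher number from compound 1 to compound 3 (0.25 log units; within the scatter) is a modest one toward a weaker inhibitor in this assay and may not stand far beyond the usual scatter. Compound 3 is expected at 70 nM (estimated range 20 nM to 300 nM).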

Compound 3, half-maximal inhibitory concentration: 47 nM
The estimate for compound 3 lay 1.5-fold (0.17 log units) above the measured number; the measured number falls inside the stated range.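

Methoxy in place of chloro on this aromatic carbon gives a 1.2-fold higher number from compound 1 to compound 3 (0.08 log units; within the scatter) in this assay, so the two groups cannot be told apart in this read-out. Within the data shown here, this is the first pair here that differs in one place only, and it shows that this position, meta to a fused ring and para to a fused ring, can carry methoxy, with 2 heavy atoms and 1 hydrogen-bond acceptor, as well as chloro, with 1 heavy atom and none, while the result stays within the scatter. Compound 2, whose result of > 1000 nM is a limit and not a number, differs from the other two compounds in more than one place, so it says nothing about this swap.

Nothing measured here bears on why chloro and methoxy read alike. From the compounds shown here alone, it also stays open whether this aromatic carbon would take an amine, a carboxylic acid or a longer alkoxy chain equally well, or whether a plain hydrogen there would give a similar result, and one swap at one position supports no wider rule.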